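Amide to acid on a shortened chain from compound 1

The source may hold more compounds than are shown below. What is called first, only, known or untested is meant among the compounds shown, and "the series" means these compounds.

Compound 1 `NC(=O)CCCC/C=C(\c1ccccc1)c1cccnc1` gives 400 nM in an assay (Equus caballus) for inhibition of Thromboxane-A synthase (Homo sapiens), using microsomes; on this read-out higher numbers stand for weaker inhibition and lower numbers for stronger inhibition. Among the three compounds measured so far, compound 1 returns the highest number. Compound 3 `C/C(=C\CCCCC(=O)O)c1cccnc1` gives 210 nM in this assay; its gap to compound 1 lies within the scatter, so the two cannot be ordered. Compound 2 `O=C(O)CCCC/C=C(\c1cccnc1)c1cccs1` gives 20 nM in this assay, and its gap to compound 1 lies beyond the scatter, so compound 2 is the stronger inhibitor of that pair.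

Compound 4 `O=C(O)CCC/C=C(\c1ccccc1)c1cccnc1` is not yet measured. It differs from compound 1 in a single place: carboxy in place of carbamoylmethyl on a saturated chain carbon, three bonds along the chain from a double-bonded chain carbon. Among the compounds with values here, no step between two measured compounds matches this change. Both measured compounds carrying a carboxy group, compound 2 and compound 3, return lower numbers than compound 1, yet each also differs from compound 1 elsewhere, so neither isolates the amide-to-acid exchange or the shortening of the chain. Weighing this, the expectation for compound 4 is a lower number than for compound 1, a step of a 4.4-fold lower number from compound 1 to compound 4 (0.65 log units; beyond the scatter), likely beyond the scatter though uncertain in size. Compound 4 is accordingly estimated at 90 nM, within a range from 25 nM to 320 nM.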

Compound 4, half-maximal inhibitory concentration: 30 nM
Compound 4: middle estimate off by 3.0-fold (0.48 log units), on the high side, within the range that was stated.
By their numbers in this assay, from the lowest: compounds 2 and 4 (each within the scatter of the next); then compounds 3 and 1 (each within the scatter of the next).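

In this assay, within the data shown here, carboxy in place of carbamoylmethyl on a saturated chain carbon, three bonds along the chain from a double-bonded chain carbon, gives a 13-fold lower number from compound 1 to compound 4 (1.12 log units; beyond the scatter), the first step in which the rest of the structure stays fixed. The earlier carboxy compounds, compound 2 and compound 3, also differ from compound 1 elsewhere, whereas this step ties a large change to the chain end alone, read as 4-carbamoylbutyl to 3-carboxypropyl, so that the end group and the chain length change together. No measurement at hand explains the size of this step.

The compounds shown leave open how much of the step belongs to the carboxylic acid and how much to the shorter chain: on the core of compound 1, a 4-carboxybutyl chain and a 3-carbamoylpropyl chain would each separate the two changes. Also open, going by these compounds, is whether the step holds for other end groups on this chain, such as a methyl ester or a tetrazole, and for a longer chain ending in a carboxylic acid.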